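The source may report more compounds than this note shows. Statements on the series, on what has been measured and on what is new or still open speak of the compounds shown alone.

Measured so far in an ADME assay on L02 cells (Homo sapiens) for inhibition, read by MTT assay, with a stated time of 48 h, tested at 100 uM; on this read-out higher numbers stand for more inhibition at the one concentration tested (going by the name of the read-out) and lower numbers for less inhibition:

- compound 1, `COc1ccc(OC)c(-c2nc(=O)ss2)c1`, gives 23.7%
- compound 2, `COc1cccc(-c2nc(=O)ss2)c1`, gives 38.6%
- compound 3, `COc1ccc(OC)c(-c2nsc(=O)o2)c1`, gives 25.3%

Compound 1 and compound 2 differ in one place, (hydrogen in place of methoxy on an aromatic carbon). That single change produced a number 14.9 percentage points higher from compound 1 to compound 2 (beyond the scatter) in this assay.

Compound 3 carries the same substitution pattern on the six-membered ring as compound 1 but a different core; the difference between the two cores is not broken down here. Their values in this assay lie within the scatter of each other, so nothing can be said about an order between compound 1 and compound 3.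

Compound 4, `COc1cccc(-c2nsc(=O)o2)c1`, has not been measured. Among the compounds with values here, it differs from compound 3 by hydrogen in place of methoxy on an aromatic carbon, which is the same change as the one from compound 1 to compound 2, made on the core of compound 3 instead. Within the data shown here, only this one precedent exists, and it shows the shift beyond the scatter. Carrying it over, the expected step is a number 13.7 percentage points higher from compound 3 to compound 4 (beyond the scatter), because the same change gave a number 14.9 percentage points higher from compound 1 to compound 2 (beyond the scatter) in the first pair. Compound 4 is therefore estimated at 39%, with a plausible range from 27% to 51%; the range is wide since one pair is a thin basis and the core is not the same.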

Compound 4, a percentage reported as inhibition, at one concentration (the size of the read-out at that concentration, not a potency): 15%
The estimate for compound 4 lay 24 percentage points above the measured number, outside the stated range (below it).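

In this assay, hydrogen in place of methoxy on an aromatic carbon gave a number 10.3 percentage points lower from compound 3 to compound 4 (beyond the scatter), so the direction of the step seen on the core of compound 1 did not carry over to the core of compound 3. In these two pairs, the outcome of the change differs with the core, and the earlier step cannot be transferred as a fixed increment: the same change on two cores in this assay, a number 14.9 percentage points higher (beyond the scatter) from compound 1 to compound 2 and a number 10.3 percentage points lower (beyond the scatter) from compound 3 to compound 4, 25.2 percentage points apart, beyond the scatter of two such steps This rests on two pairs only and does not show which feature of the cores separates the two steps, or how the same change would run on any third core.

The compounds shown vary only methoxy against hydrogen on the six-membered ring, so it remains open how an amine, a carboxylic acid or a longer chain in place of that methoxy would read on either core. As far as these compounds go, with one concentration tested, it also remains open whether the opposite steps would persist across a full concentration range.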